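A few compounds are considered here, and "the series" means these few. Any claim that something is new, unique, unknown or untested is made for them only; others in the source may bear on it.

Compound 1 `CCCn1c(=O)[nH]c2nc(-c3ccc(S(=O)(=O)N4CCN(Cc5cccc(C)c5)CC4)cc3)[nH]c2c1=O`: 0.397 nM
Compound 2 `CCCn1c(=O)[nH]c2nc(-c3ccc(S(=O)(=O)N(C)C)cc3)[nH]c2c1=O`: 18.6 nM

In an assay on CHO cells for displacement of a labelled ligand from adenosine receptor A2b (Homo sapiens), read by scintillation counting, with a stated time of 75 min, in the presence of a further agent that is not named here (a lower number here means a stronger inhibitor, a higher number a weaker inhibitor), compound 1 gives 0.397 nM, the lower of the two numbers, with compound 2 at 18.6 nM, a gap beyond the scatter. Compound 3 `CCCn1c(=O)[nH]c2nc(-c3ccc(S(=O)(=O)N4CCN(c5cccc(Br)c5)CC4)cc3)[nH]c2c1=O` carries the change (3-bromophenyl in place of 3-methylbenzyl on an amine nitrogen in a ring). Among the measured compounds shown here, no measured pair shows this change, so compound 1 is the only guide. Because compound 1 gives 0.397 nM, the step of a 2.5-fold higher number from compound 1 to compound 3 (0.40 log units; beyond the scatter) is expected to be small, toward a slightly higher number or none beyond the scatter. Compound 3 is estimated at 1 nM, with a range from 0.3 nM to 4 nM.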

Compound 3, inhibition constant: 0.234 nM
For compound 3 the middle estimate is 4.3-fold (0.63 log units) above the measured one, outside the stated range (below it).
By their numbers in this assay, from the lowest: compounds 3 and 1 (each within the scatter of the next); then compound 2.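

In this assay, replacing 3-methylbenzyl with 3-bromophenyl on the amine nitrogen in the ring gives a 1.7-fold lower number from compound 1 to compound 3 (0.23 log units; within the scatter). At this position, the two groups cannot be told apart, even though they differ in size and in the substituent they carry. No evidence here bears on this result. The change alters several features at once, leaving their separate contributions unresolved. As far as these compounds go, it also remains open whether a plain phenyl, a pyridine ring or a phenyl bearing a carboxylic acid would fit this position equally well.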